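This account rests on a few compounds, and the source may have more. Where it says the series, first, only, none or still open, it means among the compounds named here.

In an ADME assay on Vero cells (Chlorocebus sabaeus) for cytotoxicity, read by resazurin assay, with a stated time of 72 h (a higher number here means that more compound is needed for the effect, a lower number that less compound is needed), compound 2, `FC(F)(F)SCCOc1cccc(Oc2ccccc2)c1`, gives > 20 uM, which is a limit of the assay and not a number. Compound 1, `FC(F)(F)[Se]CCOc1ccc(Oc2ccccc2)cc1`, gives > 20 uM, and that too is a limit. Both measured compounds therefore rest at the limit of > 20 uM in this assay, at which 2 of the 2 values shown sit, so compound 2 has no exact position on the scale. Compound 3, `FC(F)(F)[Se]CCOc1cccc(Oc2ccccc2)c1`, differs from compound 2 in one place, on a saturated chain carbon, two bonds along the chain from an oxygen on an aromatic ring: a group of 5 heavy atoms (1 carbon, 3 fluorine, 1 selenium; no ring) in place of a group of 5 heavy atoms (1 carbon, 3 fluorine, 1 sulfur; no ring), on a saturated chain carbon, two bonds along the chain from an oxygen on an aromatic ring. Within the data shown here, no measured pair isolates this change, so no step beyond the scatter is expected in this assay, in either direction. Among the measured compounds shown here, the only guide is compound 1, which carries the same selenium-containing group and stays at its limit of > 20 uM. The expected change is a number no higher from compound 2 to compound 3 (the limit leaves the size open), an estimate only. For compound 3, the estimated value is 20 uM, with an expected range of 10 uM to 40 uM.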

Compound 3, concentration for half-maximal effect: > 20 uM
Compound 3 was reported as a limit; the forecaster's own chance of this, stated with the estimate: 70%; the middle value lies on the limit itself.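

Compound 2 and compound 3 each sit at a limit and not at a number, so no step between them can be read in this assay: the limit of > 20 uM in this assay, at which 3 of the 3 values shown sit.

The compounds shown leave open what concentration any of them needs for the effect, and whether the selenium-containing group differs from the (trifluoromethyl)sulfanyl group at all.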